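Swapping the benzyl ring for a benzothiophene

The source may hold more compounds than are shown below. What is called first, only, known or untested is meant among the compounds shown, and "the series" means these compounds.

Measured so far:
- compound 1 `COc1ccc(CN(c2cc(OC)c(OC)c(OC)c2)S(=O)(=O)c2ccc(OC)c(OC)c2)cc1`: 20100 nM
- compound 2 `COc1ccc(CN(c2cc(OC)c(OC)c(OC)c2)S(=O)(=O)c2c(C)cc(C)cc2C)cc1`: 14800 nM
- compound 3 `COc1cc(N(Cc2ccc(Cl)cc2)S(=O)(=O)c2ccc(C)cc2)cc(OC)c1OC`: 14600 nM

All three compounds share a core of a trimethoxyphenyl sulfonamide carrying a benzyl group on nitrogen, tested in a functional assay on PC-3 cells (Homo sapiens) for inhibition, read by MTT assay, with a stated time of 48 h; on this read-out higher numbers stand for weaker inhibition and lower numbers for stronger inhibition. Compound 3 gives 14600 nM, the lowest of the three numbers, though its gaps to compound 2 and to compound 1 both lie within the scatter, so no ordering among them can be claimed.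

Within the data shown here, the only one-place step measured, a 1.4-fold lower number from compound 1 to compound 2 (0.13 log units; within the scatter), changes the aryl group on the sulfonyl sulfur and stays within the scatter.

Compound 4 `COc1cc(N(Cc2csc3ccc(Cl)cc23)S(=O)(=O)c2ccc(C)cc2)cc(OC)c1OC` differs from compound 3 elsewhere: 5-chloro-1-benzothiophen-3-yl in place of 4-chlorophenyl on a saturated chain carbon bound to a sulfonamide nitrogen. Among the measured compounds shown here, no measured step touches this position, so there is nothing to indicate a direction, and the one step that exists was small.

The expectation is therefore that compound 4 shows no step beyond the scatter, a 1.2-fold lower number from compound 3 to compound 4 (0.09 log units; within the scatter), with an estimated value of 12000 nM in this assay, between 4000 nM and 40000 nM.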

Compound 4, half-maximal inhibitory concentration: 15300 nM
Estimate against measurement, compound 4: 1.3-fold (0.11 log units) below; the measured number falls inside the stated range.
By their numbers in this assay, from the lowest: compounds 3, 2, 4 and 1 (each within the scatter of the next).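

In this assay, swapping 4-chlorophenyl for 5-chloro-1-benzothiophen-3-yl gives a 1.0-fold higher number from compound 3 to compound 4 (0.02 log units; within the scatter), the first step read at this place, on a saturated chain carbon bound to a sulfonamide nitrogen. The entering group is larger and adds a five-membered aromatic ring with a sulfur atom, yet the number does not shift beyond the scatter, so this enlargement of the group leaves the read-out effectively unchanged. No measurement is available to explain this result.

As far as these compounds go, it remains open whether any group in this place can move the number beyond the scatter, for example an amine, a carboxylic acid or a longer chain. From the compounds shown here alone, it is also open whether the same result would hold for the benzothiophene without its chlorine.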